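Adding a Cyano Group to the Benzyl Ring of Compound 3

A few compounds are considered here, and "the series" means these few. Any claim that something is new, unique, unknown or untested is made for them only; others in the source may bear on it.

Compound 1 `CCN(CC)CCCOc1c(OCc2ccccc2)cc(O)c2c(=O)cc(-c3ccccc3)oc12`: 4900 nM
Compound 2 `CCN(CC)CCCCOc1c(OCc2ccccc2)cc(O)c2c(=O)cc(-c3ccccc3)oc12`: 4880 nM
Compound 3 `CN1CCN(CCCCOc2c(OCc3ccccc3)cc(O)c3c(=O)cc(-c4ccccc4)oc23)CC1`: 2370 nM

All three were measured in a functional assay on B16 cells (Mus musculus) for cytotoxicity, read by MTT assay, with a stated time of 72 h; a higher number here means a weaker inhibitor, a lower number a stronger inhibitor. Compound 3 stands lowest of the three, with steps of a 2.1-fold lower number from compound 1 to compound 3 (0.32 log units; beyond the scatter) and a 2.1-fold lower number from compound 2 to compound 3 (0.31 log units; beyond the scatter), both beyond the scatter. The step of a 1.0-fold lower number from compound 1 to compound 2 (0.00 log units; within the scatter) lies within the scatter.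

Compound 4 `CN1CCN(CCCCOc2c(OCc3ccc(C#N)cc3)cc(O)c3c(=O)cc(-c4ccccc4)oc23)CC1` differs from compound 3 by cyano in place of hydrogen on an aromatic carbon. Going by the values given here, none of the measured steps touches this ring; all three concern the amine at the end of the chain, so they give no direct guide to this change. With nothing pointing either way, the expected step is a 1.0-fold higher number from compound 3 to compound 4 (0.01 log units; within the scatter), none beyond the scatter. Compound 4 is therefore estimated at 2400 nM, with a range of 1000 nM to 6000 nM.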

Compound 4, half-maximal inhibitory concentration: 3700 nM
Compound 4: middle estimate off by 1.5-fold (0.19 log units), on the low side, within the range that was stated.
By their numbers in this assay, from the lowest: compounds 3, 4, 2 and 1 (each within the scatter of the next, the first and the last beyond it).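

Going by these compounds alone, this is the first change on the benzyl ring; the earlier steps only varied the amine at the end of the chain. Going from benzyl to 4-cyanobenzyl gives a 1.6-fold higher number from compound 3 to compound 4 (0.19 log units; within the scatter) in this assay and so shows that this ring position accepts a nitrile without a change that can be told from ordinary repeat variation. No measurement available here offers an explanation for this result.

On these data alone, whether a larger group at the same place, such as a methoxy group or a carboxylic acid, would shift the number remains open. So does whether the nitrile would behave the same way alongside the diethylamino chains.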